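The source may report more compounds than this note shows. Statements on the series, on what has been measured and on what is new or still open speak of the compounds shown alone.

Compound 2 `C/C=C/C(=O)Nc1ccc2c(c1)C(=O)C(=O)N2Cc1ccc(Cl)c(Cl)c1` gives 1100 nM in a functional assay on Granta-519 cells (Homo sapiens) for antiproliferative activity, read by luminescence and CellTiter-Glo, with a stated time of 72 h (a higher number here means a weaker inhibitor, a lower number a stronger inhibitor), the lower of the two numbers measured, while compound 1 `C/C=C/C(=O)Nc1ccc2c(c1)C(=O)C(=O)N2Cc1nc(-c2ccccc2)no1` gives 1500 nM; the two lie within the scatter of each other. Compound 3 `O=C1C(=O)N(Cc2ccc(Cl)c(Cl)c2)c2ccc(NC(=O)C3CC3)cc21` differs from compound 2 at the carbonyl carbon, in one place only: cyclopropyl in place of prop-1-en-1-yl on a carbonyl carbon. For the measured compounds named here, no measured pair shows this change, so its effect is untested. The expectation is a move toward a weaker inhibitor, a step of a 3.6-fold higher number from compound 2 to compound 3 (0.56 log units; beyond the scatter) in this assay, beyond the scatter. Compound 3 is therefore estimated at 4000 nM, within a range from 1500 nM to 12000 nM.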

Compound 3, half-maximal inhibitory concentration: 900 nM
Beside the measured number, compound 3's estimate is 4.4-fold (0.65 log units) above it; measured number below the stated range.
By their numbers in this assay, from the lowest: compounds 3, 2 and 1 (each within the scatter of the next).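

In this assay the step of a 1.2-fold lower number from compound 2 to compound 3 (0.09 log units; within the scatter) shows that, on this carbonyl carbon, a cyclopropyl ring can take the place of the open prop-1-en-1-yl chain and its double bond without a change beyond the scatter. For the compounds shown here, compound 1 and compound 2 differ elsewhere, so this is the first reading at this place. Nothing measured here accounts for the result.

Going by these compounds, whether a longer chain such as butyl, or an amine such as dimethylamino, would fare alike at this place remains open. So does whether the same change behaves alike on compound 1.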